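Ester-bearing secondary amine replaces the butyl(ethyl)amino group

This account rests on a few compounds, and the source may have more. Where it says the series, first, only, none or still open, it means among the compounds named here.

Measured compounds:
compound 1, `CCC(COC)N(C)c1nc(C)nc2c1nnn2-c1ccc(C(C)C)cc1Br`: 11.2 nM
compound 2, `CCN(CC)c1nc(C)nc2c1nnn2-c1ccc(C(C)C)cc1Br`: 25.3 nM
compound 3, `CCCCN(CC)c1nc(C)nc2c1nnn2-c1ccc(C(C)C)cc1Br`: 7.5 nM

In an in vitro assay on 293-EBNA cells for binding affinity to corticotropin-releasing factor receptor 1 (Homo sapiens) (on this read-out lower numbers stand for stronger inhibition and higher numbers for weaker inhibition), compound 3 gives the lowest of the three numbers. Its nearest neighbour is compound 1, the gap being a 1.5-fold lower number from compound 1 to compound 3 (0.17 log units; within the scatter); the larger gap is a 3.4-fold lower number from compound 2 to compound 3 (0.53 log units; beyond the scatter). Compound 4, `CCC(Nc1nc(C)nc2c1nnn2-c1ccc(C(C)C)cc1Br)C(=O)OC`, differs from compound 3 by a group of 8 heavy atoms (5 carbon, 1 nitrogen, 2 oxygen; no ring) in place of a group of 7 heavy atoms (6 carbon, 1 nitrogen; no ring), on an aromatic carbon.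

The measured steps only touch the edges of this change. The step of a 2.3-fold higher number from compound 1 to compound 2 (0.35 log units; beyond the scatter) shows that trimming the amine substituent costs some affinity, and a 3.4-fold lower number from compound 2 to compound 3 (0.53 log units; beyond the scatter) shows that lengthening it gains some. Among the compounds with values here, compound 4 keeps a branched chain of similar length but exchanges the tertiary amine for one bearing a hydrogen-bond donor and an ester, a change for which no measured step exists. The author therefore expects compound 4 to be weaker than compound 3, by roughly an 8.0-fold higher number from compound 3 to compound 4 (0.90 log units; beyond the scatter). Compound 4 is estimated at 60 nM, with a range from 15 nM to 250 nM.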

Compound 4, inhibition constant: 19.4 nM
Estimate against measurement, compound 4: 3.1-fold (0.49 log units) above; the range from low to high includes it.
By their numbers in this assay, from the lowest: compounds 3, 1, 4 and 2 (each within the scatter of the next, the first and the last beyond it).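

In this assay the group with 1 hydrogen-bond donor and 3 hydrogen-bond acceptors costs only a modest amount against butyl(ethyl)amino (a 2.6-fold higher number from compound 3 to compound 4 (0.41 log units; beyond the scatter)). Against the two other tertiary amines, the change stays within the scatter (a 1.3-fold lower number from compound 2 to compound 4 (0.12 log units; within the scatter) and a 1.7-fold higher number from compound 1 to compound 4 (0.24 log units; within the scatter)), so this position on the shared core tolerates a secondary amine carrying an ester with affinity in the range of those amines. No measurement shown here bears on why the numbers fall as they do.

Compound 4 brings the hydrogen on the amine nitrogen and the ester together, so the compounds shown do not separate their contributions to the step from butyl(ethyl)amino. Also open, from the compounds shown here alone, is whether a carboxylic acid or a primary amide in place of the ester would hold affinity, and whether adding a methyl group on the amine nitrogen of compound 4 would recover the modest loss.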